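Substituent swaps on the sulfonyl aryl ring leave cytotoxicity unchanged

The source may hold more compounds than are shown below. What is called first, only, known or untested is meant among the compounds shown, and "the series" means these compounds.

Of the compounds shown here, three built on one shared core have been tested. Compound 1 `O=C1/C(=C/c2ccccc2F)CN(S(=O)(=O)c2ccccc2)C/C1=C\c1ccccc1F` carries an unsubstituted phenylsulfonyl group; in an ADME assay on L02 cells (Homo sapiens) for cytotoxicity, read by MTT assay, with a stated time of 24 h (on this read-out lower numbers stand for stronger inhibition and higher numbers for weaker inhibition), compound 1 gives 17600 nM. Compound 2 `Cc1ccc(S(=O)(=O)N2C/C(=C\c3ccccc3F)C(=O)/C(=C/c3ccccc3F)C2)cc1` bears a methyl on that aryl ring, and in this assay compound 2 gives 16700 nM. Compound 3 `O=C1/C(=C/c2ccccc2F)CN(S(=O)(=O)c2ccc(Br)cc2)C/C1=C\c1ccccc1F` bears a bromo instead, and in this assay compound 3 gives 16200 nM. Compound 3 holds the lowest of the three numbers, yet every gap to it is within the scatter: a 1.1-fold lower number from compound 1 to compound 3 (0.04 log units; within the scatter) and a 1.0-fold lower number from compound 2 to compound 3 (0.01 log units; within the scatter), while a 1.1-fold lower number from compound 1 to compound 2 (0.02 log units; within the scatter).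

Compound 4 `N#Cc1ccc(S(=O)(=O)N2C/C(=C\c3ccccc3F)C(=O)/C(=C/c3ccccc3F)C2)cc1` has not yet been measured. It differs from compound 3 in one place: cyano in place of bromo on an aromatic carbon. The two steps that bear on this position, the bromo-for-hydrogen step and the bromo-for-methyl step, were each too small to rise above the scatter, so substituents on this aromatic carbon have so far not moved the read-out. On that basis, the number for compound 4 in this assay is expected to stay close to that of compound 3, with a 1.0-fold lower number from compound 3 to compound 4 (0.01 log units; within the scatter) not expected to exceed the scatter. The estimate for compound 4 is 16000 nM, within a range from 8000 nM to 32000 nM.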

Compound 4, half-maximal inhibitory concentration: 11000 nM
For compound 4 the middle estimate is 1.5-fold (0.16 log units) above the measured one, within the range that was stated.
By their numbers in this assay, from the lowest: compounds 4, 3, 2 and 1 (each within the scatter of the next).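

Replacing bromo with cyano adds a triple bond and a hydrogen-bond acceptor that bromo lacks, yet in this assay the result is a 1.5-fold lower number from compound 3 to compound 4 (0.17 log units; within the scatter), and the comparisons with the other two groups give a 1.5-fold lower number from compound 2 to compound 4 (0.18 log units; within the scatter) and a 1.6-fold lower number from compound 1 to compound 4 (0.20 log units; within the scatter). Across the four compounds, this aromatic carbon has therefore accepted hydrogen, methyl, bromo and cyano with no step beyond the scatter, and the first group carrying a hydrogen-bond acceptor at this position does not break that pattern. No available evidence bears on why the read-out stays within this band.

The compounds shown leave open whether an amine, a carboxylic acid or a longer chain on this aromatic carbon would also stay within the scatter of these four compounds, or would be the first group to produce a real step. They also leave open whether the read-out would respond to a change elsewhere on the shared core, such as replacing the fluoro groups on its two fluorinated aromatic rings with methoxy groups, since only the group on the sulfonyl aryl ring varies here.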